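Compound 3 to compound 4: a carbonyl for the sulfonyl

This account rests on a few compounds, and the source may have more. Where it says the series, first, only, none or still open, it means among the compounds named here.

In a functional assay on DLD-1 cells (Homo sapiens) for cytotoxicity, read by resazurin assay, with a stated time of 48 h (a higher number here means that more compound is needed for the effect, a lower number that less compound is needed), compound 3 `COc1ccc(S(=O)(=O)Nc2ccc3oc(-c4ccc(NS(=O)(=O)c5cc(Br)ccc5OC)cc4)nc3c2)cc1` gives 15000 nM, the highest of three numbers. Compound 1 `COc1ccc(S(=O)(=O)Nc2ccc3oc(-c4ccc(NC(=O)c5cccc(C)c5[N+](=O)[O-])cc4)nc3c2)cc1` gives 1500 nM, and compound 2 `COc1ccc(S(=O)(=O)Nc2ccc3oc(-c4ccc(NC(=O)c5ccc(Cl)s5)cc4)nc3c2)cc1` gives 4600 nM.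

Compound 4 `COc1ccc(S(=O)(=O)Nc2ccc3oc(-c4ccc(NC(=O)C5CCN(C(C)=O)CC5)cc4)nc3c2)cc1` carries (1-acetylpiperidin-4-yl)carbonyl in place of (5-bromo-2-methoxyphenyl)sulfonyl on a nitrogen on an aromatic ring.

The closest evidence is the same sulfonyl and carbonyl exchange, read in reverse, in a 10-fold higher number from compound 1 to compound 3 (1.00 log units; beyond the scatter) and a 3.3-fold higher number from compound 2 to compound 3 (0.51 log units; beyond the scatter). Both steps are modest and beyond the scatter. The group on the carbonyl also matters, as a 3.1-fold higher number from compound 1 to compound 2 (0.49 log units; beyond the scatter) shows, and neither measured amide carries a non-aromatic ring. A modest move to a lower number is therefore expected in this assay, with an estimated step of a 2.5-fold lower number from compound 3 to compound 4 (0.40 log units; beyond the scatter). Compound 4 is estimated at 6000 nM, within a range of 2000 nM to 18000 nM.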

Compound 4, half-maximal effective concentration: 15000 nM
Estimate against measurement, compound 4: 2.5-fold (0.40 log units) below; the measured number falls inside the stated range.
By their numbers in this assay, from the lowest: compound 1; then compound 2; then compounds 3 and 4 (each within the scatter of the next).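

In this assay the carbonyl on this nitrogen does not by itself lower the number, with no change at the digits printed from compound 3 to compound 4 (within the scatter) when (1-acetylpiperidin-4-yl)carbonyl replaces (5-bromo-2-methoxyphenyl)sulfonyl. Among the amides, the numbers separate with the group on the carbonyl carbon: 1-acetylpiperidin-4-yl gives a 3.3-fold higher number from compound 2 to compound 4 (0.51 log units; beyond the scatter) against 5-chlorothiophen-2-yl and a 10-fold higher number from compound 1 to compound 4 (1.00 log units; beyond the scatter) against 3-methyl-2-nitrophenyl. No measurement here gives a reason for these steps.

The compounds shown leave open whether the acetyl group on the piperidine matters, as a piperidin-4-yl with a free amine would test. An unsubstituted phenyl on the carbonyl would show how much of the lower numbers of compound 1 and compound 2 needs the substituents on their aromatic rings.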